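Swapping the amine head group on compound 1

This account rests on a few compounds, and the source may have more. Where it says the series, first, only, none or still open, it means among the compounds named here.

Going by the values given here, compound 1, `C[C@H](Nc1nc(N)nc(N)c1C#N)c1nn(-c2cccc(S(C)(=O)=O)c2)c2cc(F)ccc12`, is one of three compounds measured in a functional assay on Bel-7402 cells (Homo sapiens) for inhibition, read by sulforhodamine B assay, with a stated time of 72 h, tested at 10 uM (on this read-out higher numbers stand for more inhibition at the one concentration tested (going by the name of the read-out) and lower numbers for less inhibition), where compound 1 gives 14%. That places compound 1 second highest of the three: compound 2, `C[C@H](Nc1nc(N)nc2[nH]cnc12)c1nn(-c2cccnc2)c2cc(F)ccc12`, gives -5%, while compound 3, `C[C@H](Nc1nc(N)nc(N)c1C#N)c1nn(-c2cccc(S(C)(=O)=O)c2)c2cc(Cl)ccc12`, gives 47%. Among the compounds with values here, the only single-point step among them, a number 33 percentage points higher from compound 1 to compound 3 (beyond the scatter), concerns a different position from the one changed here.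

Compound 4, `C[C@H](Nc1ncnc2[nH]cnc12)c1nn(-c2cccc(S(C)(=O)=O)c2)c2cc(F)ccc12`, differs from compound 1 in this way: a group of 9 heavy atoms (5 carbon, 4 nitrogen; one five-membered aromatic ring with 2 hetero atoms, one six-membered aromatic ring with 2 hetero atoms) in place of a group of 10 heavy atoms (5 carbon, 5 nitrogen; one six-membered aromatic ring with 2 hetero atoms), on an amine nitrogen. Within the data shown here, no measured step covers this exact exchange. A head group of the same two-ring kind is carried by compound 2, which also differs elsewhere, so the value of compound 2, -5%, offers only a loose hint that such a head group sits lower. The step from compound 1 to compound 4 is therefore expected to be small, likely downward, and probably within the scatter, as a number 7 percentage points lower from compound 1 to compound 4 (within the scatter). Compound 4 is estimated to give 7%, with a range from -10% to 26%.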

Compound 4, a percentage reported as inhibition, at one concentration (the size of the read-out at that concentration, not a potency): -16%
Compound 4: middle estimate off by 23 percentage points, on the high side; the whole stated range lies above it.
By their numbers in this assay, from the lowest: compound 4; then compound 2; then compound 1; then compound 3.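

With the rest of the molecule held fixed, the exchange at the amine nitrogen gives a number 30 percentage points lower from compound 1 to compound 4 (beyond the scatter) in this assay. Going by these compounds alone, until now, the only single-place step had been the swap of chloro for fluoro on an aromatic carbon, so this is the first sign that the group on the amine nitrogen can by itself move the read-out beyond the scatter, here in the downward direction. Nothing in the available data accounts for the drop.

The compounds shown leave open which part of the departing group matters, as the step exchanges the whole group at once and no pair separates the nitrile from the amino groups. Also open, as far as these compounds go, are how a morpholine or a carboxylic acid would read on this head group, and whether the two-ring group gives a similar step with chloro in place of fluoro.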